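The compounds below may be only part of what the source reports. "The series", "measured", "known", "first", "only" and "open" are said of these compounds alone.

For the measured compounds named here, in a functional assay on MCF7 cells (Homo sapiens) for antiproliferative activity, read by MTT assay, with a stated time of 48 h (a higher number here means a weaker inhibitor, a lower number a stronger inhibitor), compound 2 `Fc1ccc(C2=NN(c3nc(-c4ccc(Br)cc4)cs3)C(c3cccs3)C2)cc1` gives 8280 nM, the lower of the two numbers measured so far; compound 1 `COc1ccc(C2=NN(c3nc(-c4ccc(Br)cc4)cs3)C(c3cccs3)C2)cc1` gives 21200 nM. Compound 3 `Cc1ccc(C2=NN(c3nc(-c4ccc(Br)cc4)cs3)C(c3cccs3)C2)cc1` is compound 2 with methyl in place of fluoro on an aromatic carbon. Going by the values given here, the only measured step at that position, a 2.6-fold lower number from compound 1 to compound 2 (0.41 log units; beyond the scatter), exchanged a different group, so it gives no direct guide to replacing fluoro with methyl. With nothing pointing clearly either way, the expected step is a 1.1-fold higher number from compound 2 to compound 3 (0.04 log units; within the scatter), within the scatter. Compound 3 is therefore estimated at 9000 nM, with a range from 3000 nM to 30000 nM.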

Compound 3, half-maximal inhibitory concentration: 2010 nM
For compound 3 the middle estimate is 4.5-fold (0.65 log units) above the measured one, and the stated range ends above it.
By their numbers in this assay, from the lowest: compound 3; then compound 2; then compound 1.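

Replacing fluoro with methyl on the six-membered aromatic ring gives a 4.1-fold lower number from compound 2 to compound 3 (0.61 log units; beyond the scatter) in this assay and shows that this position still responds strongly to a change between two small groups. Methyl also compares well with methoxy, with an 11-fold lower number from compound 1 to compound 3 (1.02 log units; beyond the scatter), so from the lowest number to the highest the groups run methyl, fluoro, methoxy. Nothing available explains why these groups differ. Going by these compounds, it remains open whether ethyl, chloro or an amine at this place would lower the number further, and whether methyl keeps its advantage when other parts of the shared core change.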